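A few compounds are considered here, and "the series" means these few. Any claim that something is new, unique, unknown or untested is made for them only; others in the source may bear on it.

Measured compounds:
`COc1ccc(Nc2nnnn2-c2ccccc2Cl)cc1` compound 1: 100000 nM
`COc1ccc(-n2nnnc2Nc2ccccc2Cl)cc1` compound 2: 134000 nM

In an ADME assay on HaCaT cells (Homo sapiens) for cytotoxicity, read by MTT assay, with a stated time of 72 h (on this read-out higher numbers stand for weaker inhibition and lower numbers for stronger inhibition), compound 1 gives 100000 nM, the lowest of the two numbers. Compound 2 gives 134000 nM, and the gap between the two lies within the scatter, so they cannot be told apart on this read-out. Compound 3 `COc1ccc(Nc2nnnn2-c2ccc(F)cc2)cc1` has not been measured; it differs from compound 1 by 4-fluorophenyl in place of 2-chlorophenyl on an aromatic nitrogen. Going by the values given here, no measured step covers this kind of change, so the expected step from compound 1 to compound 3 is no change at the digits printed from compound 1 to compound 3 (within the scatter), none beyond the scatter. Compound 3 is therefore expected at 100000 nM, within a range from 40000 nM to 250000 nM.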

Compound 3, half-maximal inhibitory concentration: 101000 nM
Compound 3: middle estimate off by 1.0-fold (0.00 log units), on the low side; measured number inside the range.
By their numbers in this assay, from the lowest: compounds 1, 3 and 2 (each within the scatter of the next).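

Going by these compounds alone, this is the first measured step at this position: in this assay, 4-fluorophenyl in place of 2-chlorophenyl on the aromatic nitrogen gives a 1.0-fold higher number from compound 1 to compound 3 (0.00 log units; within the scatter) in this read-out. The two halogen-bearing phenyl groups therefore cannot be told apart here, and no supporting data bear on why. On these data alone, whether a different group at this position, such as a pyridine ring or a short alkyl chain, would give a number beyond the scatter stays open. So does the effect of replacing the methoxy group with an amine.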